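This account rests on a few compounds, and the source may have more. Where it says the series, first, only, none or still open, it means among the compounds named here.

Three compounds have been measured in a functional assay on the whole organism (strain NMRI) with Mus musculus as the target, with a stated time of 60 min, at a dose of 20 mg/kg by the intraperitoneal route; a higher number here means a stronger effect of the compound at the dose given, a lower number a weaker effect:

compound 1 `CCCSc1nnc(Cc2ccccc2Oc2ccccc2)[nH]1`, 158%
compound 2 `c1ccc(CSc2nnc(Cc3ccccc3Oc3ccccc3)[nH]2)cc1`, 143%
compound 3 `CCCSc1nnc(Cc2ccc(Cl)cc2Oc2ccccc2Cl)[nH]1`, 134%

Compound 4 `Clc1ccc(Cc2nnc(SCc3ccccc3)[nH]2)c(Oc2ccccc2Cl)c1` has not yet been measured in this assay.

Compound 1 and compound 2 share a core and differ in one place: phenyl in place of ethyl on a saturated chain carbon bound to a sulfur. That change gives a number 15 percentage points lower from compound 1 to compound 2 (beyond the scatter), a modest fall that lies beyond the usual scatter of this measurement. Compound 3 carries a different core; how its core differs from that of compound 1 is not broken down here. The value of compound 3 stands within the scatter of that of compound 2, while it sits beyond the scatter below that of compound 1.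

Compound 4 is related to compound 3 by the same change: phenyl in place of ethyl on a saturated chain carbon bound to a sulfur. The place of the change reads the same in both pairs, so it is the same change seen a second time, now on the core of compound 3. For the measured compounds named here, only one measured instance of it exists, and whether it carries over to the other core is not known from these data. Resting on the step of a number 15 percentage points lower from compound 1 to compound 2 (beyond the scatter) seen between compound 1 and compound 2, a step of similar size is expected here: a number 15 percentage points lower from compound 3 to compound 4 (beyond the scatter). Compound 4 is therefore estimated at 119%, with the range from 104% to 134% expected to hold most repeat measurements.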

Compound 4, a percentage reported as activity, at one dose (the size of the read-out at that dose, not a potency): 129%
Estimate against measurement, compound 4: 10 percentage points below; measured number inside the range.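

In this assay, the change from propylsulfanyl to benzylsulfanyl on the core of compound 3 gives a number 5 percentage points lower from compound 3 to compound 4 (within the scatter), and this step does not part from the one seen on the core of compound 1: the same change on two cores in this assay, a number 15 percentage points lower (beyond the scatter) from compound 1 to compound 2 and a number 5 percentage points lower (within the scatter) from compound 3 to compound 4, 10 percentage points apart, within the scatter of two such steps. The two instances are therefore compatible with a single step of similar size carrying over from one core to the other, so the earlier step was a usable guide here. They do not establish it as a rule: there are only two instances, one lying beyond the scatter and the other within it, so it stays unsettled whether the change has any real effect on the core of compound 3, and nothing is shown for any third core.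

Only propyl and benzyl stand on the sulfur in the compounds shown, so it remains open how a longer chain, an amine or a carboxylic acid at that place would read out, and whether the step would hold for them. From the compounds shown here alone, it is also open whether the same picture would appear at other doses, as each number here is the size of the effect at one dose and not a potency.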